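The source may hold more compounds than are shown below. What is called first, only, known or untested is meant among the compounds shown, and "the series" means these compounds.

Measured so far in a functional assay on PC-3 cells (Homo sapiens) for antiproliferative activity, read by MTT assay, with a stated time of 72 h; a higher number here means a weaker inhibitor, a lower number a stronger inhibitor: compound 1 `O=S(=O)(c1ccc(-c2cnc(C3CC3)o2)cc1)N1CCCOc2cc(F)ccc21` gives 42 nM, compound 2 `O=[N+]([O-])c1ccc2c(c1)OCCCN2S(=O)(=O)c1ccc(-c2cnc(C3CC3)o2)cc1` gives 72 nM, and compound 3 `O=[N+]([O-])c1ccc2c(c1)N(S(=O)(=O)c1ccc(-c3cnc(C4CC4)o3)cc1)CCCO2` gives 119 nM.

Compound 2 and compound 1 differ in one place, (fluoro in place of nitro on an aromatic carbon), and that step was a 1.7-fold lower number from compound 2 to compound 1 (0.23 log units; within the scatter). Compound 3 has the same atoms as compound 2 joined differently; the difference between the two cores is not broken down here. Compound 4 `O=S(=O)(c1ccc(-c2cnc(C3CC3)o2)cc1)N1CCCOc2ccc(F)cc21` stands to compound 3 as compound 1 stands to compound 2: the change is fluoro in place of nitro on an aromatic carbon, the same change at a place described in the same words. Because the earlier step was a 1.7-fold lower number from compound 2 to compound 1 (0.23 log units; within the scatter), a step of similar size is expected here, a 1.7-fold lower number from compound 3 to compound 4 (0.23 log units; within the scatter). Compound 4 is therefore estimated at 70 nM, expected to lie between 35 nM and 140 nM.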

Compound 4, half-maximal inhibitory concentration: 18 nM
Compound 4: the middle estimate sits 3.9-fold (0.59 log units) above what was measured; the whole stated range lies above it.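

Fluoro in place of nitro gives a 6.6-fold lower number from compound 3 to compound 4 (0.82 log units; beyond the scatter) in this assay. The same change does not give a step of the same size on the two cores: the same change on two cores in this assay, a 1.7-fold lower number (0.23 log units; within the scatter) from compound 2 to compound 1 and a 6.6-fold lower number (0.82 log units; beyond the scatter) from compound 3 to compound 4, 3.9-fold (0.59 log units) apart, beyond the scatter of two such steps So in this series, a step measured on one core cannot simply be copied to the other; these two pairs do not show why the cores differ, and they give no general rule for this change.

The compounds shown leave open what other groups in these places, such as an amine, a nitrile or a methoxy group, would give on either core. Going by these compounds, whether such groups would also show a gap between the two cores remains open too.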